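The source may hold more compounds than are shown below. What is called first, only, known or untested is meant among the compounds shown, and "the series" means these compounds.

In an ADME assay on HepG2 2.2.15 cells (Homo sapiens) for cytotoxicity, read by CCK-8 assay, with a stated time of 8 days (a higher number here means that more compound is tolerated, a lower number that less compound is tolerated), compound 3 `COc1cccc(C(=O)Nc2c[nH]c(=O)c(-c3cccc(C)c3)c2)c1O` gives > 100000 nM, which is a limit of the assay and not a number. On these data alone, that places compound 3 at the limit of > 100000 nM in this assay, at which 1 of the 3 values shown sits, so its exact standing among the compounds is unknown.

The next compound, compound 4 `CCOc1ccc(-c2cc(NC(=O)c3cccc(OC)c3O)c[nH]c2=O)cc1`, changes one group: 4-ethoxyphenyl in place of 3-methylphenyl on an aromatic carbon. In words, 4-ethoxyphenyl comes in place of 3-methylphenyl on an aromatic carbon.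

For the measured compounds named here, only one measured step bears on this directly, and it concerns a different position. Going an at least 1.0-fold higher number from compound 2 to compound 3 (0.00 log units; that floor lies within the scatter), a methoxy replaces a hydrogen on an aromatic carbon, and this step does not go beyond the scatter. Compound 2 `Cc1cccc(-c2cc(NC(=O)c3ccccc3O)c[nH]c2=O)c1` gives 98800 nM.

The closest guide is compound 1 `COc1ccc(-c2cc(NC(=O)c3ccc(C)cc3O)c[nH]c2=O)cc1`, which gives 46100 nM. It carries a methoxy on the ring where compound 4 has its ethoxy, although it also differs from compound 4 elsewhere. On the strength of the 46100 nM shown by compound 1, a modest move toward a lower number is expected in this assay. Compound 4 could still reach only the limit.

The estimated step is an at least 1.5-fold lower number from compound 3 to compound 4 (0.18 log units; that floor lies within the scatter). The expected value for compound 4 is 65000 nM, with an estimated range of 30000 nM to 100000 nM.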

Compound 4, half-maximal cytotoxic concentration: 34500 nM
The estimate for compound 4 lay 1.9-fold (0.28 log units) above the measured number; measured number inside the range.
By their numbers in this assay, from the lowest: compounds 4 and 1 (each within the scatter of the next); then compound 2. At a limit, above all of these: compound 3.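

In this assay, putting 4-ethoxyphenyl in place of 3-methylphenyl on this aromatic carbon gives an at least 2.8-fold lower number from compound 3 to compound 4 (0.46 log units; beyond the scatter), so less of the compound is tolerated. The size of this step is only a floor, as the value for compound 3 is a limit of the assay and not a number: the limit of > 100000 nM in this assay, at which 1 of the 4 values shown sits. The only earlier step, a methoxy in place of a hydrogen at a different position, an at least 1.0-fold higher number from compound 2 to compound 3 (0.00 log units; that floor lies within the scatter), did not go beyond the scatter, so this is the first change shown to make a clear difference in this assay, and it marks this aromatic carbon as a place where the choice of group matters.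

The change alters two things at once, the group on the phenyl ring and where it sits, so 3-methylphenyl and 4-ethoxyphenyl alone cannot show which of the two accounts for the drop. On these data alone, it also remains open whether a longer chain at the same place on the phenyl ring would lower the number further, and whether an amine or a carboxylic acid there would lower it or raise it.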